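The source may report more compounds than this note shows. Statements on the series, on what has been measured and on what is new or still open speak of the compounds shown alone.

Of the compounds shown here, two from one series have been tested in a functional assay on the whole organism (strain Swiss albino) for inhibition, with Mus musculus as the target, in the formalin test, with stated times of 30 min and 5 min, at a dose of 100 mg/kg (a lower number here means less inhibition, a higher number more inhibition at the dose given (going by the name of the read-out)), so far. Compound 1, `CCN1CCc2c(c(C(C)(C)C)nn2C(=O)Nc2ccc(Br)cc2)C1`, gives 0% in this assay, and compound 2, `CCN1CCc2c(c(C(C)(C)C)nn2C(=O)Nc2cc(C)ccc2F)C1`, gives 7%. The two differ only in the group on the amide-type nitrogen, and the step of a number 7 percentage points higher from compound 1 to compound 2 (within the scatter) is too small to tell the two apart. Compound 2 therefore stands at the top of the two numbers seen, but only by an amount that repeated testing would blur.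

Compound 3, `CCN1CCc2c(c(C(C)(C)C)nn2C(=O)Nc2ccc(Cl)cc2)C1`, is the next compound in line. Compared with compound 2 the change is 4-chlorophenyl in place of 2-fluoro-5-methylphenyl on an amide-type nitrogen. Going by the values given here, the only measured step that bears on this change is the one from compound 1 to compound 2, also a swap of the aryl group on the amide-type nitrogen, and that step stayed within the scatter. With both measured numbers sitting near the floor of the read-out, compound 3 is expected to show essentially no inhibition either, and the expected step of a number 4 percentage points lower from compound 2 to compound 3 (within the scatter) is none beyond the scatter. The estimate for compound 3 in this assay is 3%, expected to fall between 0% and 15%.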

Compound 3, a percentage reported as inhibition, in the whole organism at one dose (the size of the read-out at that dose, not a potency): 3.5%
Compound 3: middle estimate off by 0.5 percentage points, on the low side; the range from low to high includes it.
By their numbers in this assay, from the lowest: compounds 1, 3 and 2 (each within the scatter of the next).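

In this assay, replacing one aryl group with another on the amide-type nitrogen gives a number 3.5 percentage points lower from compound 2 to compound 3 (within the scatter), a second aryl swap at this position that does not separate two compounds. The closest comparison so far is the exchange of a single halogen atom on the ring, chloro in place of bromo on an aromatic carbon, which gives a number 3.5 percentage points higher from compound 1 to compound 3 (within the scatter), so this exchange also makes no readable difference, and the three aryl groups shown cannot be told apart in this test. No measurement is available that could explain this shared result.

As far as these compounds go, all three groups on the amide-type nitrogen are six-membered aromatic rings of carbon bearing a halogen, so it remains open whether a ring carrying an amine or a carboxylic acid, or a benzyl group with its extra carbon, would lift the read-out clear of the scatter. The compounds shown also leave open how the read-out responds to changes elsewhere on the shared core, which is the same in all three.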